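The source may hold more compounds than are shown below. What is called first, only, known or untested is meant among the compounds shown, and "the series" means these compounds.

Of the compounds shown here, three have been measured in an ADME assay on LLC-MK2 cells (Macaca mulatta) for cytotoxicity, read by spectrophotometry and crystal violet staining, with a stated time of 4 days; on this read-out lower numbers stand for higher toxicity in this test and higher numbers for lower toxicity in this test. Compound 1 `CC(C)n1ncc2c(C(=O)Nc3ncccn3)cc(-c3ccsc3)nc21` gives 50000 nM in this assay. Compound 2 `CC(C)n1ncc2c(C(=O)Nc3ncccn3)cc(-c3cccs3)nc21` differs from compound 1 by thiophen-2-yl in place of thiophen-3-yl on an aromatic carbon. In this assay compound 2 gives 75000 nM. The step of a 1.5-fold higher number from compound 1 to compound 2 (0.18 log units; within the scatter) lies within the scatter. Compound 3 `CC(C)n1ccc2c(C(=O)Nc3ccc(F)cc3)cc(-c3cccs3)nc21` gives > 200000 nM in this assay, a limit of the assay and not a number. Of the two numbers available, compound 2 holds the higher, with compound 1 the nearest, yet the gap between them is within the scatter, so no order between them can be read.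

Compound 4 `CC(C)n1ncc2c(C(=O)Nc3cccc(F)c3F)cc(-c3cccs3)nc21` follows from compound 2 by 2,3-difluorophenyl in place of pyrimidin-2-yl on an amide-type nitrogen. Among the compounds with values here, no measured step changes the group on the amide-type nitrogen; the one measured step, from compound 1 to compound 2, concerns another part of the molecule and stays within the scatter. Compound 3, which differs from compound 2 in more than one place, sits at the limit of > 200000 nM in this assay, at which 1 of the 3 values shown sits. The data therefore give no ground to expect a step beyond the scatter for compound 4, although a limit result remains possible. Compound 4 is estimated at 100000 nM, with a range from 40000 nM to 250000 nM. The step from compound 2 that this estimate means is expected to be a 1.3-fold higher number from compound 2 to compound 4 (0.12 log units; within the scatter).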

Compound 4, half-maximal cytotoxic concentration: 75000 nM
Compound 4: the middle estimate sits 1.3-fold (0.12 log units) above what was measured; the range from low to high includes it.
By their numbers in this assay, from the lowest: compounds 1, 2 and 4 (each within the scatter of the next). At a limit, above all of these: compound 3.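

In this assay, within the data shown here, the group on the amide-type nitrogen is varied for the first time, and 2,3-difluorophenyl in place of pyrimidin-2-yl gives no change at the digits printed from compound 2 to compound 4 (within the scatter). The earlier step concerned only the thiophene attachment, whereas this one replaces a six-membered aromatic ring with 2 hetero atoms and 2 hydrogen-bond acceptors by a six-membered aromatic ring of carbon only and 0 hydrogen-bond acceptors, and for this single pair the read-out shows no difference beyond the scatter. Nothing given here bears on why the two groups read alike.

On these data alone, what remains open is whether this holds beyond one pair on one core, and whether an amine or a carboxylic acid on the ring at this nitrogen, or a longer chain in place of that ring, would produce a step beyond the scatter. Compound 3 gives > 200000 nM, a limit and not a number, and as it differs from the other compounds in more than one place, it cannot settle this question.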